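The source may hold more compounds than are shown below. What is called first, only, known or untested is meant among the compounds shown, and "the series" means these compounds.

Three compounds share a common core and were tested in a functional assay on HepG2 cells (Homo sapiens) for cytotoxicity, read by MTT assay, with a stated time of 72 h; a higher number here means that more compound is tolerated, a lower number that less compound is tolerated. Compound 2 `C[Se]/C(=N\C(=O)c1sccc1Cl)NC(=O)c1sccc1Cl` gives 8670 nM. Compound 3 `C[Se]/C(=N\C(=O)c1cnc2ccccc2c1)NC(=O)c1cnc2ccccc2c1` gives 87800 nM, the higher of the two numbers and a gap beyond the usual scatter. Compound 1 `C[Se]/C(=N\C(=O)c1ccco1)NC(=O)c1ccco1` reaches only the limit of this assay, > 100000 nM, (the limit of > 100000 nM in this assay, at which 1 of the 3 values shown sits). No two of these compounds differ in just one place, so no single change has a measured effect here. Compound 4 `CS/C(=N\C(=O)c1cnc2ccccc2c1)NC(=O)c1cnc2ccccc2c1` differs from compound 3 by a group of 2 heavy atoms (1 carbon, 1 sulfur; no ring) in place of a group of 2 heavy atoms (1 carbon, 1 selenium; no ring), on a carbon with a double bond to nitrogen. Among the compounds with values here, with no measured step to lean on, the expected change in this assay is a 1.1-fold higher number from compound 3 to compound 4 (0.06 log units; within the scatter), that is, none beyond the scatter. Compound 4 is therefore estimated at 100000 nM, likely between 40000 nM and 250000 nM.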

Compound 4, concentration lethal to 50% of the cells: > 100000 nM
Compound 4 was reported as a limit; the forecaster's own chance of this, stated with the estimate: 45%; the middle value lies on the limit itself.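

Within the data shown here, compound 3 and compound 4 form the first pair here that differs in one place, so replacing the selenium-containing group with methylsulfanyl, on a carbon with a double bond to nitrogen, can now be read in this assay: the step is an at least 1.1-fold higher number from compound 3 to compound 4 (0.05 log units; that floor lies within the scatter). This is only a floor, so the pair does not show a real change from the swap. The value of compound 4 is a limit, shared with compound 1: the limit of > 100000 nM in this assay, at which 2 of the 4 values shown sit.

As far as these compounds go, whether the same swap would give a clearer reading on the cores of compound 1 and compound 2 remains open. So does the effect of an amine or a longer chain at this place.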